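A Methyl Added Beside the Chain Hydroxyl

This account rests on a few compounds, and the source may have more. Where it says the series, first, only, none or still open, it means among the compounds named here.

Measured so far:
compound 1, `COC[C@H]1CN(c2ccc(OCC[C@@H](C)OC)cc2)C(=O)O1`: 2.7
compound 2, `COC[C@H]1CN(c2ccc(OCCCCO)cc2)C(=O)O1`: 1.84

Among the compounds with values here, compound 2 holds the lower of the two numbers in a physicochemical assay for lipophilicity; on this read-out higher numbers stand for higher lipophilicity and lower numbers for lower lipophilicity; the only measured step runs a number 0.86 log units lower from compound 1 to compound 2 (beyond the scatter). Compound 3, `COC[C@H]1CN(c2ccc(OCCCC(C)O)cc2)C(=O)O1`, differs from compound 2 by methyl in place of hydrogen on a saturated chain carbon bound to an oxygen on a saturated carbon and a saturated chain carbon. Within the data shown here, no measured step shows this change on its own. The step from 1-methoxyethyl to 2-hydroxyethyl (a number 0.86 log units lower from compound 1 to compound 2 (beyond the scatter)) bundles the loss of one methyl with the move of the oxygen-bound group, so it only hints at what one extra methyl is worth here. In this assay a single added methyl on a chain is usually worth a small to modest rise, so a step of about a number 0.41 log units higher from compound 2 to compound 3 (beyond the scatter) is expected for compound 3. Compound 3 is therefore estimated at 2.25, with a likely range from 1.95 to 2.6.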

Compound 3, partition coefficient: 2.27
For compound 3 the middle estimate is 0.02 log units below the measured one; low and high end bracket the measured number.
By their numbers in this assay, from the lowest: compound 2; then compound 3; then compound 1.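

Methyl in place of hydrogen on a saturated chain carbon bound to an oxygen on a saturated carbon and a saturated chain carbon now has a size of its own in this assay: a number 0.43 log units higher from compound 2 to compound 3 (beyond the scatter), with no other change mixed in. The second step, 2-hydroxypropyl in place of 1-methoxyethyl, gives a number 0.43 log units lower from compound 1 to compound 3 (beyond the scatter), so compound 3 sits about midway between the other two compounds, and the two steps are of equal size. No measurement at hand gives a reason for either step.

From the compounds shown here alone, what ethyl in place of this methyl, or an amine in place of the hydroxyl, would do to this number stays open. So does whether the added methyl would be worth the same on a longer chain.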